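An Amino Group in Place of Chloro on a Uracil Acetamide

This account rests on a few compounds, and the source may have more. Where it says the series, first, only, none or still open, it means among the compounds named here.

Measured so far in a functional assay on MCF7 cells (Homo sapiens) for inhibition, read by MTT assay, with a stated time of 72 h; a higher number here means a weaker inhibitor, a lower number a stronger inhibitor:
compound 2 `O=C(CCl)Nc1c[nH]c(=O)[nH]c1=O` gives 15000 nM
compound 1 `CC(C)(C)OC(=O)NCCNCC(=O)Nc1c[nH]c(=O)[nH]c1=O` gives > 100000 nM
compound 3 `Cc1c(I)c(=O)[nH]c(=O)n1COC(CO)CO` gives > 100000 nM

Among the compounds with values here, compound 2 holds the only number in this set; its value in this assay is 15000 nM. For compound 1 the assay reports only a limit, > 100000 nM. For compound 3 the assay likewise reports only a limit, > 100000 nM. The set is thus dominated by the limit of > 100000 nM in this assay, at which 2 of the 3 values shown sit.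

Compound 4 `NCC(=O)Nc1c[nH]c(=O)[nH]c1=O` has not yet been measured. It differs from compound 2 by amino in place of chloro on a saturated chain carbon bound to a carbonyl carbon. Within the data shown here, no step between two measured compounds is available for comparison. The other compound of this core that lacks the chloro is compound 1, which reached only the limit > 100000 nM. On that basis the step of a 5.3-fold higher number from compound 2 to compound 4 (0.73 log units; beyond the scatter) is expected to be a loss of potency beyond the usual scatter. Compound 4 is therefore estimated at 80000 nM, within a range of 20000 nM to 300000 nM, with a real chance that only a limit is reported.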

Compound 4, half-maximal inhibitory concentration: > 100000 nM
Compound 4: a limit, no number; the forecaster's own chance of this, stated with the estimate: 60%; middle value at least 1.2-fold (0.09 log units) from the limit.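

Amino in place of chloro on a saturated chain carbon bound to a carbonyl carbon gives an at least 6.6-fold higher number from compound 2 to compound 4 (0.82 log units; beyond the scatter) in this assay, the first comparison in this set that isolates a single change at this position. Compound 4 gives only a limit, so the step has a lower bound but no exact size. Among the compounds sharing this core, only compound 2, which carries chloromethyl, gives a number, while compound 4 joins the other compounds at the limit: the limit of > 100000 nM in this assay, at which 3 of the 4 values shown sit.

The compounds shown leave open whether chloro itself is needed at this place or whether bromo or a hydroxyl group would also give a number in this assay. They also leave open how a longer chain carrying the chloro would compare with compound 2.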